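Adding a second acyl group to a chain acylguanidine

The source may report more compounds than this note shows. Statements on the series, on what has been measured and on what is new or still open speak of the compounds shown alone.

Measured compounds:
Compound 1 `CC(C)=CCC/C(C)=C/CC/C(C)=C/C(=O)NC(=N)N` gives 10000 nM in a functional assay on Hs 683 cells (Homo sapiens) for inhibition, read by MTT assay, with a stated time of 72 h; a lower number here means a stronger inhibitor of growth, a higher number a weaker inhibitor of growth.
Compound 2 `C=C1CCCC(C)(C)[C@@H]1CC/C(C)=C/C(=O)NC(=N)NC(=O)C=C(C)C` gives 18100 nM in this assay.

Both measured compounds carry a guanidine that is acylated on one nitrogen by an unsaturated terpene-derived chain. Compound 1 has an open chain and a free amine nitrogen on the guanidine. Compound 2 has a ring-containing chain and carries a second acyl group on the guanidine. In this assay the two numbers sit within the usual scatter of each other, so neither compound stands apart from the other.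

Compound 3 `CC(C)=CCC/C(C)=C/CC/C(C)=C/C(=O)NC(=N)NC(=O)C=C(C)C` is compound 1 with the change ((2-methylprop-1-en-1-yl)carbonyl in place of hydrogen on an amine nitrogen). This gives compound 3 the same second acyl group that compound 2 carries, while keeping the open chain of compound 1. Compound 2 shows that a guanidine bearing this second acyl group can give a number close to that of compound 1, so no step beyond the scatter is expected in either direction in this assay. The step of a 1.2-fold higher number from compound 1 to compound 3 (0.08 log units; within the scatter) is the expected outcome. Compound 3 is therefore estimated at 12000 nM, with a range from 4000 nM to 40000 nM.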

Compound 3, concentration for 50% growth inhibition: 8300 nM
For compound 3 the middle estimate is 1.4-fold (0.16 log units) above the measured one; the measured number falls inside the stated range.
By their numbers in this assay, from the lowest: compounds 3, 1 and 2 (each within the scatter of the next, the first and the last beyond it).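

In this assay, putting (2-methylprop-1-en-1-yl)carbonyl in place of hydrogen on an amine nitrogen gives a 1.2-fold lower number from compound 1 to compound 3 (0.08 log units; within the scatter). Among these compounds, compound 1 and compound 3 differ in this one place only, so this step is the first direct reading of the second acyl group, which the comparison of compound 1 with compound 2 could not give, as their chains also differ; on the open chain, this amine nitrogen takes the added group and its 6 heavy atoms, and the loss of its hydrogen, with no change beyond the scatter. No measurement here offers any explanation for this result.

From the compounds shown here alone, it remains open whether a different group on this nitrogen, such as a simple acetyl, a longer acyl chain or an acyl chain ending in a carboxylic acid, would move the number beyond the scatter. Also open, going by these compounds, is whether the step holds on the ring-containing chain of compound 2, a question that would need that chain paired with hydrogen on the same amine nitrogen.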